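Amide aryl variation on the shared core: benzofuran step

This account rests on a few compounds, and the source may have more. Where it says the series, first, only, none or still open, it means among the compounds named here.

Measured compounds:
compound 1 `CN1[C@@H]2c3[nH]c4ccccc4c3C[C@H]1[C@H](C#N)N1[C@@H](CNC(=O)c3cccc(C(F)(F)F)c3)c3[nH]c4ccccc4c3C[C@@H]21` gives 630 nM in a functional assay on HCT-116 cells (Homo sapiens) for cytotoxicity, read by MTT assay, with a stated time of 72 h; on this read-out lower numbers stand for stronger inhibition and higher numbers for weaker inhibition
compound 2 `CN1[C@@H]2c3[nH]c4ccccc4c3C[C@H]1[C@H](C#N)N1[C@@H](CNC(=O)c3ccc4ccccc4c3)c3[nH]c4ccccc4c3C[C@@H]21` gives 420 nM in this assay

Both measured compounds share one core and differ only in the aryl group on the amide carbonyl. Compound 2 carries the lowest of the two numbers, but its nearest neighbour is compound 1, and the step of a 1.5-fold lower number from compound 1 to compound 2 (0.18 log units; within the scatter) lies within the scatter, so the two cannot be placed in order of potency on these data.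

The next compound, compound 3 `CN1[C@@H]2c3[nH]c4ccccc4c3C[C@H]1[C@H](C#N)N1[C@@H](CNC(=O)c3cc4ccccc4o3)c3[nH]c4ccccc4c3C[C@@H]21`, is built from compound 2 by the change (1-benzofuran-2-yl in place of naphthalen-2-yl on a carbonyl carbon). Among the measured compounds shown here, the only measured step that bears on it is the aryl swap on the same carbonyl, a 1.5-fold lower number from compound 1 to compound 2 (0.18 log units; within the scatter), which moved the number by no more than the scatter. One step is a thin basis, yet it gives no sign that the aryl group at this position shifts the read-out strongly.

For compound 3 the expected outcome in this assay is therefore a step of about a 1.2-fold higher number from compound 2 to compound 3 (0.08 log units; within the scatter), that is, no change beyond the scatter. The estimate for compound 3 is 500 nM, with a range from 200 nM to 1200 nM.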

Compound 3, half-maximal inhibitory concentration: 330 nM
Compound 3: the middle estimate sits 1.5-fold (0.18 log units) above what was measured; the measured number falls inside the stated range.
By their numbers in this assay, from the lowest: compounds 3, 2 and 1 (each within the scatter of the next).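

In this assay, a 1.3-fold lower number from compound 2 to compound 3 (0.10 log units; within the scatter), so an exchange that brings a five-membered aromatic ring with 1 hetero atom and 1 hydrogen-bond acceptor onto the carbonyl carbon does not move the read-out beyond the scatter. Among the compounds shown here, the wider comparison, a 1.9-fold lower number from compound 1 to compound 3 (0.28 log units; within the scatter), also stays within the scatter, so 3-(trifluoromethyl)phenyl, naphthalen-2-yl and 1-benzofuran-2-yl cannot be told apart at this position, and the aromatic oxygen of 1-benzofuran-2-yl adds no readable difference to the single aryl swap seen earlier. No measurement is available that bears on why these three values stay so close.

Still open, from the compounds shown here alone, is whether anything other than an aryl group on this carbonyl would give a step beyond the scatter, for example an aliphatic amine, a carboxylic acid or a longer alkyl chain in place of the ring. Going by these compounds, the nitrile and the rest of the shared core are the same in all three compounds, so what changes there would do to the number also remains unknown.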